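Changing the amide partner of a cyclopentyl ether

The source may report more compounds than this note shows. Statements on the series, on what has been measured and on what is new or still open speak of the compounds shown alone.

Compound 1 `COc1ccc(C(=O)Nc2ccccc2Cl)cc1OC1CCCC1` gives the lowest number among the values shown in an assay on isolated protein for inhibition of phosphodiesterase 4A (Sus scrofa); on this read-out lower numbers stand for stronger inhibition and higher numbers for weaker inhibition: compound 1 gives 190 nM. Its nearest companion is compound 3 `COc1ccc(C(=O)Nc2ccccc2Cl)cc1OC(C)=O`, which gives 70000 nM. Compound 2 `COc1ccc(C(=O)Nc2ccccc2Cl)cc1OC(=O)c1ccccc1` reaches only a limit of the assay, > 1000000 nM, so no number is known for it; this is the limit of > 1000000 nM in this assay, at which 1 of the 3 values shown sits.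

The two measured steps away from compound 1 both touch the oxygen on the aromatic ring: an at least 5200-fold higher number from compound 1 to compound 2 (3.72 log units; beyond the scatter) and a 370-fold higher number from compound 1 to compound 3 (2.57 log units; beyond the scatter), with an at least 14-fold lower number from compound 2 to compound 3 (1.15 log units; beyond the scatter) between the two esters. Both are large losses when the cyclopentyl is replaced by an acyl group.

Compound 4 `COc1ccc(C(=O)Nc2cccnc2)cc1OC1CCCC1` keeps the cyclopentyl ether intact and differs from compound 1 only at the amide: pyridin-3-yl in place of 2-chlorophenyl on an amide-type nitrogen. Among the compounds with values here, none of the measured steps alters this part of the molecule, so they say nothing direct about the size of this change. Without a comparison at the amide nitrogen, the expectation is a modest shift rather than a loss of the kind seen at the ether oxygen. Compound 4 is therefore estimated to give 500 nM in this assay, between 50 nM and 5000 nM, which would mean an expected step of a 2.6-fold higher number from compound 1 to compound 4 (0.42 log units; beyond the scatter).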

Compound 4, half-maximal inhibitory concentration: 550 nM
Compound 4: the middle estimate sits 1.1-fold (0.04 log units) below what was measured, within the range that was stated.
By their numbers in this assay, from the lowest: compound 1; then compound 4; then compound 3. At a limit, above all of these: compound 2.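

Until now every measured change sat on the oxygen on the aromatic ring; this one sits on an amide-type nitrogen, and in this assay putting pyridin-3-yl in place of 2-chlorophenyl gives a 2.9-fold higher number from compound 1 to compound 4 (0.46 log units; beyond the scatter). This shows that the amide partner does affect the read-out, but that this replacement costs far less than exchanging the cyclopentyl for acetyl on the oxygen, which gives a 370-fold higher number from compound 1 to compound 3 (2.57 log units; beyond the scatter). The swap removes the chlorine and brings in the ring nitrogen in a single step, and nothing shown gives a reason for the size of this step.

Still open, from the compounds shown here alone, is how a plain phenyl, a pyridin-2-yl or a pyridin-4-yl would read on the same amide-type nitrogen with the cyclopentyl ether kept, since such compounds would help separate the part played by the chlorine from that of the ring nitrogen. Also open is how a cyclohexyl or an ethyl on the oxygen on the aromatic ring would compare with the cyclopentyl, since the only replacements shown there are acetyl and benzoyl.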